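A few compounds are considered here, and "the series" means these few. Any claim that something is new, unique, unknown or untested is made for them only; others in the source may bear on it.

- compound 1 `O=C1Nc2c(ncn2Cc2ccccc2)C(C#CC2CC2)N1Cc1ccccc1`: 1.3 ug/mL
- compound 2 `O=c1nc2c(ncn2Cc2ccccc2)c(C#Cc2ccccc2)n1Cc1ccccc1`: 0.7 ug/mL

In a functional assay on K562 cells (Homo sapiens) for cytotoxicity, read by thymidine incorporation, with a stated time of 48 h (a lower number here means a stronger inhibitor, a higher number a weaker inhibitor), compound 2, at 0.7 ug/mL, stands within the scatter of compound 1, so the two numbers do not separate. Compound 3 `O=c1nc2c(ncn2Cc2ccccc2)c(C(F)(F)F)n1Cc1ccccc1` carries trifluoromethyl in place of 2-phenylethynyl on an aromatic carbon of compound 2: trifluoromethyl in place of 2-phenylethynyl on an aromatic carbon. Going by the values given here, no measured pair covers this change, so the expectation is only loosely grounded: a moderate move towards a weaker inhibitor in this assay, with no change beyond the scatter still possible. The estimated step is a 3.6-fold higher number from compound 2 to compound 3 (0.55 log units; beyond the scatter). Compound 3 is expected at 2.5 ug/mL, within an estimated range of 0.8 ug/mL to 8 ug/mL.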

Compound 3, half-maximal inhibitory concentration: > 10 ug/mL
Compound 3: no number, only a limit (the forecaster's own chance of this, stated with the estimate: 5%); middle value at least 4.0-fold (0.60 log units) from the limit.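

In this assay, replacing 2-phenylethynyl with trifluoromethyl on this aromatic carbon gives an at least 14-fold higher number from compound 2 to compound 3 (1.15 log units; beyond the scatter), so activity here depends strongly on the substituent. Compound 1 and compound 2 both carry a triple bond in this substituent, whereas compound 3 is the first shown without one. Compound 3 gives only a limit of the assay, not a number: the limit of > 10 ug/mL in this assay, at which 1 of the 3 values shown sits.

This single change removes the triple bond and the phenyl ring together, so their contributions cannot be separated. A saturated 2-phenylethyl chain or an amine on this carbon would help to separate them.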